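Adding One Carbon to the Side Chain

The source may report more compounds than this note shows. Statements on the series, on what has been measured and on what is new or still open speak of the compounds shown alone.

Going by the values given here, compound 2 `CCCc1cc2ccccc2nc1-c1cc(-c2ccc(C(F)(F)F)cc2)no1` is the only compound here with a measured number: in a functional assay on A549 cells (Homo sapiens) for inhibition, read by MTT assay, with a stated time of 24 h (on this read-out higher numbers stand for weaker inhibition and lower numbers for stronger inhibition), compound 2 gives 43900 nM. Compound 1 `CCCCc1cc2ccccc2nc1-c1cc(-c2ccccc2)no1` carries a butyl chain and a plain phenyl; in this assay compound 1 gives > 100000 nM, which is a limit of the assay rather than a number. Compound 3 `CCCCc1cc2ccccc2nc1-c1cc(-c2ccc(C(F)(F)F)cc2)no1` keeps the trifluoromethylphenyl of compound 2 and differs from it only by methyl in place of hydrogen on a saturated chain carbon, three bonds along the chain from an aromatic carbon, propyl becoming butyl. Among the compounds with values here, no measured pair isolates this change, so the step of a 1.3-fold higher number from compound 2 to compound 3 (0.10 log units; within the scatter) is expected to stay within the usual scatter, leaning slightly weaker. Compound 3 is expected to give 55000 nM, within 20000 nM to 150000 nM.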

Compound 3, half-maximal inhibitory concentration: 9400 nM
For compound 3 the middle estimate is 5.9-fold (0.77 log units) above the measured one; measured number outside the range, below it.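

On this assay, the methyl that turns propyl into butyl gives a 4.7-fold lower number from compound 2 to compound 3 (0.67 log units; beyond the scatter), so one added carbon at this place on the chain clearly moves the read-out when the trifluoromethylphenyl is present. With the butyl chain held constant, trifluoromethyl in place of hydrogen on an aromatic carbon gives an at least 10-fold lower number from compound 1 to compound 3 (1.02 log units; beyond the scatter). Compound 1, the starting point of that step, is a limit of the assay and not a number: the limit of > 100000 nM in this assay, at which 1 of the 3 values shown sits.

From the compounds shown here alone, whether a pentyl chain would continue this direction remains open. So does the effect of an amine or a carboxylic acid on the chain.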